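Series notes on cytotoxicity in RD cells

This account rests on a few compounds, and the source may have more. Where it says the series, first, only, none or still open, it means among the compounds named here.

Compound 2 `FC(F)(F)c1nc(-c2cnc3ccc(-c4ccccc4)cc3c2)no1` carries a trifluoromethyl-substituted oxadiazole on the shared core together with an unsubstituted phenyl. In a functional assay on RD cells (Homo sapiens) for inhibition, read by luminescence and ATP content, with a stated time of 72 h (on this read-out lower numbers stand for higher toxicity in this test and higher numbers for lower toxicity in this test), compound 2 gives > 22200 nM, which is a limit of the assay and not a number. Among the compounds with values here, the only other value in hand is also a limit: compound 1 `CCOC(=O)c1cnc2ccc(-c3ccc(C(C)C)cc3)cc2c1`, with an ethyl ester on the core and a 4-isopropylphenyl, gives > 7400 nM in this assay. Within the data shown here, both compounds thus sit at the ceiling of the test (the limit of > 22200 nM in this assay, at which 1 of the 2 values shown sits; (the limit of > 7400 nM in this assay, at which 1 of the 2 values shown sits)), and no measured step between them can be stated.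

Compound 3 `CC(C)c1ccc(-c2ccc3ncc(-c4noc(C(F)(F)F)n4)cc3c2)cc1` is not yet measured. It differs from compound 2 by isopropyl in place of hydrogen on an aromatic carbon, para to a large group. Compound 1, which already carries the 4-isopropylphenyl, gives only the limit > 7400 nM in this assay. No step beyond the scatter is therefore expected. The expected step from compound 2 to compound 3 is a number no higher from compound 2 to compound 3 (the limit leaves the size open). The estimate for compound 3 is 22000 nM, with a range of 7000 nM to 70000 nM, and most probably the assay again reports only a limit.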

Compound 3, half-maximal cytotoxic concentration: > 200000 nM
Compound 3: a limit, no number; the forecaster's own chance of this, stated with the estimate: 70%; middle value at least 9.0-fold (0.95 log units) from the limit.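

Compound 3 gives > 200000 nM in this assay, which is a limit of the assay and not a number. With compound 1 and compound 2 also standing only as limits, the steps from compound 2 to compound 3 and from compound 1 to compound 3 cannot be read. The compounds shown leave open what half-maximal cytotoxic concentration any of the three actually has.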